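The source may report more compounds than this note shows. Statements on the series, on what has been measured and on what is new or still open speak of the compounds shown alone.

Compound 2, `CC1(C)[C@H]2CC[C@]1(C)N(Cc1cn(-c3ccccc3C#N)nn1)C(=O)C2`, gives 240 nM in a functional assay on PANC-1 cells (Homo sapiens) for inhibition, read by MTT assay, with a stated time of 24 h; a lower number here means a stronger inhibitor, a higher number a weaker inhibitor. Its only measured neighbour, compound 1, `Cc1ccccc1-n1cc(CN2C(=O)C[C@@H]3CC[C@@]2(C)C3(C)C)nn1`, gives 250 nM in this assay, and the two values lie within the scatter of one another, so compound 2 stands level with the other number shown rather than apart from it. Compound 3, `CC1(C)[C@H]2CC[C@]1(C)N(Cc1cn(-c3ccccc3Cl)nn1)C(=O)C2`, differs from compound 2 by chloro in place of cyano on an aromatic carbon. Among the compounds with values here, no measured step touches a chloro group at this place. Within the data shown here, the one step that bears on the same position, a 1.0-fold lower number from compound 1 to compound 2 (0.02 log units; within the scatter), was within the scatter, so changing the small group on that aromatic carbon has so far left the number where it was. On that basis compound 3 is expected to stay close to compound 2, with a step of a 1.0-fold higher number from compound 2 to compound 3 (0.02 log units; within the scatter) that does not exceed the scatter. The estimate for compound 3 is 250 nM, within a range of 120 nM to 520 nM.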

Compound 3, half-maximal inhibitory concentration: 270 nM
The estimate for compound 3 lay 1.1-fold (0.03 log units) below the measured number; low and high end bracket the measured number.
By their numbers in this assay, from the lowest: compounds 2, 1 and 3 (each within the scatter of the next).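

In this assay, the position now carries a third group on the same aromatic carbon, ortho to a large group, and the numbers still do not separate: the change from cyano to chloro gives a 1.1-fold higher number from compound 2 to compound 3 (0.05 log units; within the scatter), and the change from methyl to chloro gives a 1.1-fold higher number from compound 1 to compound 3 (0.03 log units; within the scatter). Swapping two heavy atoms with a triple bond and a hydrogen-bond acceptor for one chlorine atom with no acceptor thus leaves the number within the scatter, which the single earlier step could not show. Nothing available accounts for this lack of separation.

Still open, from the compounds shown here alone, is whether the number would hold with an amine, a carboxylic acid or a longer chain on this carbon. Going by these compounds, it is also open whether chloro would give the same result on another carbon of the ring.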